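Aminomethyl on the benzamide ring: compound 3 to compound 4

The compounds below may be only part of what the source reports. "The series", "measured", "known", "first", "only" and "open" are said of these compounds alone.

Measured so far:
compound 1, `COc1cc(OCC(=O)Nc2cccc(NC(=O)c3ccc(N(C)C)cc3)c2)ccc1C=O`, 3740 nM
compound 2, `CN(C)c1ccc(C(=O)Nc2cccc(NC(=O)COc3ccc4c(c3)OCCC4=O)c2)cc1`, 144 nM
compound 3, `O=C(COc1ccc2c(=O)ccoc2c1)Nc1cccc(NC(=O)c2ccccc2)c1`, 120 nM

In an assay on isolated protein for inhibition of Rho-associated protein kinase 1 (Homo sapiens), read by scintillation counting, radiometric assay and 33P incorporation, with a stated time of 40 min, in the presence of a further agent that is not named here (on this read-out lower numbers stand for stronger inhibition and higher numbers for weaker inhibition), compound 3 gives the lowest number of the three; its nearest neighbour is compound 2, a gap within the scatter, while compound 1 lies far above it. For the measured compounds named here, the one single-point step measured in the set, a 26-fold lower number from compound 1 to compound 2 (1.41 log units; beyond the scatter), concerns the group on the oxygen of the saturated carbon, not the benzamide end. Compound 2 and compound 3 differ in two places at once, so their values show only that the two remain close to each other.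

Compound 4, `NCc1ccc(C(=O)Nc2cccc(NC(=O)COc3ccc4c(=O)ccoc4c3)c2)cc1`, differs from compound 3 by aminomethyl in place of hydrogen on an aromatic carbon. Going by the values given here, no measured step touches this position, so nothing in the set speaks for a change in either direction. The working expectation for this assay is therefore a step within the scatter, a 1.2-fold lower number from compound 3 to compound 4 (0.08 log units; within the scatter), with a wide range to reflect the missing precedent. Compound 4 is estimated at 100 nM, between 25 nM and 400 nM.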

Compound 4, half-maximal inhibitory concentration: 532 nM
The estimate for compound 4 lay 5.3-fold (0.73 log units) below the measured number, and the stated range ends below it.
By their numbers in this assay, from the lowest: compounds 3 and 2 (each within the scatter of the next); then compound 4; then compound 1.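

For the compounds shown here, this is the first measured change at the benzoyl end of the series: in this assay, aminomethyl in place of hydrogen on an aromatic carbon, para to a large group, gives a 4.4-fold higher number from compound 3 to compound 4 (0.65 log units; beyond the scatter). The position therefore responds to substitution, and with this group the number moves towards weaker inhibition. Nothing measured in the series accounts for the rise.

From the compounds shown here alone, it remains open whether the rise is specific to aminomethyl or would also follow from other groups on the same carbon, such as a methyl, a carboxylic acid or a longer aminoethyl chain. Going by these compounds, it is also open whether the same change would give a step of similar size on the core of compound 2, which carries a different group at this position.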